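Swapping Fluoro for Isopropyl: A Stability Estimate

This account rests on a few compounds, and the source may have more. Where it says the series, first, only, none or still open, it means among the compounds named here.

Compound 1 `COc1ccc(NC(=O)C(=O)c2c[nH]c3cc(C)ccc23)cc1`: 89.1%
Compound 2 `COc1ccc(NC(=O)C(=O)c2c[nH]c3cc(Cl)ccc23)cc1`: 87.3%
Compound 3 `COc1ccc(NC(=O)C(=O)c2c[nH]c3cc(F)ccc23)cc1`: 74.6%

In an ADME assay on microsomes from liver (Mus musculus) for metabolic stability, read by HPLC, with a stated time of 30 min (on this read-out higher numbers stand for a more stable compound and lower numbers for a less stable compound), compound 3 gives 74.6%, the lowest of the three numbers. The next compound to be tested, compound 4 `COc1ccc(NC(=O)C(=O)c2c[nH]c3cc(C(C)C)ccc23)cc1`, carries isopropyl in place of fluoro on an aromatic carbon.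

Three measured steps offer guidance. Fluoro in place of methyl gave a number 14.5 percentage points lower from compound 1 to compound 3 (beyond the scatter). Fluoro in place of chloro gave a number 12.7 percentage points lower from compound 2 to compound 3 (beyond the scatter). Chloro in place of methyl, by contrast, gave a number 1.8 percentage points lower from compound 1 to compound 2 (within the scatter). So far, then, the fluoro compound stands apart from the other two, and both steps that involve it are modest in size.

Compound 4 also loses fluoro, so its number is expected to rise, as if those two steps were run in reverse. However, isopropyl has not been measured in this series, and none of these steps shows how it behaves. A smaller rise than either step is therefore the cautious expectation, and the range must stay wide. The expected step is a number 6.4 percentage points higher from compound 3 to compound 4 (within the scatter).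

For compound 4, the estimated value is 81%, with an expected range of 63% to 94%.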

Compound 4, percent of the compound remaining: 86.2%
Compound 4: middle estimate off by 5.2 percentage points, on the low side; the range from low to high includes it.
By their numbers in this assay, from the lowest: compound 3; then compounds 4, 2 and 1 (each within the scatter of the next).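

The result shows that this position, an aromatic carbon para to a fused ring, also accommodates isopropyl, a branched group unlike the fluoro, chloro and methyl seen there before. In this assay, the change from fluoro to isopropyl gives a clear step (a number 11.6 percentage points higher from compound 3 to compound 4 (beyond the scatter)), while the changes from chloro and from methyl to isopropyl give small ones (a number 1.1 percentage points lower from compound 2 to compound 4 (within the scatter); a number 2.9 percentage points lower from compound 1 to compound 4 (within the scatter)), so among these four compounds only compound 3, with fluoro, stands apart, and none goes against that picture. No available measurement bears on why the compounds behave this way.

The compounds shown leave open whether this stability in this assay extends beyond the groups seen here, for instance to an amine, a carboxylic acid or a longer chain such as n-butyl at the same position. They also leave open whether the gap between fluoro and the other three groups would appear if the same changes were placed elsewhere on the shared core.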